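The compounds below may be only part of what the source reports. "The series", "measured", "known", "first", "only" and "open" are said of these compounds alone.

Working notes on the series. Compound 1 `CCCCCCCC(=O)OCC1CN(C(=O)c2cc(OC)c(OC)c(OC)c2)CCN1C(=O)c1cc(OC)c(OC)c(OC)c1` is the reference point; in a functional assay (Oryctolagus cuniculus) for inhibition of platelet-activating factor receptor (Cavia porcellus) (a lower number here means a stronger inhibitor, a higher number a weaker inhibitor), compound 1 gives 310 nM. Among the three measured numbers it stands second highest. Nearest to it is compound 2 `COc1cc(C(=O)N2CCN(C(=O)c3cc(OC)c(OC)c(OC)c3)C(COC(=O)C3CCCCC3)C2)cc(OC)c1OC`, which in this assay gives 290 nM; the step of a 1.1-fold lower number from compound 1 to compound 2 (0.03 log units; within the scatter) lies within the scatter, so the two values cannot be ordered. Furthest from it is compound 3 `COc1cc(N2CCN(c3cc(OC)c(OC)c(OC)c3)CC2)cc(OC)c1OC`, which in this assay gives 12500 nM, a number far beyond the scatter from that of compound 1; no single-point step connects these two, so only the two values themselves are noted.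

The step now followed leads from compound 1 to compound 4 `CCCC(C)NC(=O)OCC1CN(C(=O)c2cc(OC)c(OC)c(OC)c2)CCN1C(=O)c1cc(OC)c(OC)c(OC)c1`. The change is (1-methylbutyl)amino in place of heptyl on a carbonyl carbon. Among the compounds with values here, of the measured steps, only the step from compound 1 to compound 2 bears on this position, and it was within the scatter. Within the data shown here, that single step says the group on this carbonyl carbon can be exchanged without a clear shift, but it gives no direct precedent for the (1-methylbutyl)amino group entering here. The expectation in this assay is therefore a step of a 1.3-fold higher number from compound 1 to compound 4 (0.11 log units; within the scatter) that stays close to the scatter, in either direction. Compound 4 is accordingly estimated at 400 nM, with a range from 150 nM to 1200 nM.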

Compound 4, half-maximal inhibitory concentration: 100 nM
Compound 4: middle estimate off by 4.0-fold (0.60 log units), on the high side; measured number outside the range, below it.
By their numbers in this assay, from the lowest: compound 4; then compounds 2 and 1 (each within the scatter of the next); then compound 3.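

In this assay, the group on this carbonyl carbon now proves able to move the number: cyclohexyl in place of heptyl stayed within the scatter (a 1.1-fold lower number from compound 1 to compound 2 (0.03 log units; within the scatter)), whereas (1-methylbutyl)amino gives a modest step beyond it, both against heptyl (a 3.1-fold lower number from compound 1 to compound 4 (0.49 log units; beyond the scatter)) and against cyclohexyl (a 2.9-fold lower number from compound 2 to compound 4 (0.46 log units; beyond the scatter)). The two carbon-only groups cannot be ordered, yet the entering group, which carries a nitrogen and one hydrogen-bond donor, stands apart from both, so the position is not as indifferent as the first step alone suggested. Nothing shown here accounts for this shift.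

Within the data shown here, with only one such group at hand, the nitrogen, the hydrogen-bond donor and the branching of the chain all change together and cannot be told apart. A straight butylamino chain, a dimethylamino group with no amide hydrogen, or a phenylamino group on the same carbonyl carbon would show which of these features goes with the lower number, and how far the step extends.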